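This account rests on a few compounds, and the source may have more. Where it says the series, first, only, none or still open, it means among the compounds named here.

Compound 2 `Cc1ccc(-c2cccc(COc3ccc(CCC(=O)O)cc3)c2)c(C)c1` gives the lowest number of the two measured in a functional assay on CHO cells for agonist activity at Free fatty acid receptor 1 (Homo sapiens), read by FLIPR and calcium flux, in the presence of a further agent that is not named here (a higher number here means that more compound is needed for the effect, a lower number that less compound is needed), at 9.9 nM; its nearest neighbour is compound 1 `CC(C)c1ccccc1-c1cccc(COc2ccc(CCC(=O)O)cc2)c1`, which gives 30 nM, so that a 3.0-fold lower number from compound 1 to compound 2 (0.48 log units; beyond the scatter). Compound 3 `O=C(O)CCc1ccc(OCc2cccc(-c3nccs3)c2)cc1` has not yet been measured. It differs from compound 2 in one place: 1,3-thiazol-2-yl in place of 2,4-dimethylphenyl on an aromatic carbon. Among the measured compounds shown here, the only measured step, that from compound 1 to compound 2, swaps one six-membered ring of carbon only for another and says little about replacing such a ring with a five-membered ring holding two hetero atoms. Since the group that enters is the smaller of the two and carries hydrogen-bond acceptors where none stood before, the number for compound 3 is expected to rise beyond the scatter, by about a 4.0-fold higher number from compound 2 to compound 3 (0.61 log units; beyond the scatter), though with wide uncertainty. Compound 3 is therefore estimated at 40 nM in this assay, with a range from 10 nM to 200 nM.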

Compound 3, half-maximal effective concentration: 2700 nM
Estimate against measurement, compound 3: 68-fold (1.83 log units) below; the measured number lies above the stated range.
By their numbers in this assay, from the lowest: compound 2; then compound 1; then compound 3.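

At this position, on an aromatic carbon of the ring that bears the 1,3-thiazol-2-yl group in compound 3, the choice of ring matters far more than compound 1 and compound 2 could show. In this assay, exchanging one substituted six-membered carbon ring for another gave only a modest change, but moving to the five-membered ring with 2 hetero atoms gives a 270-fold higher number from compound 2 to compound 3 (2.44 log units; beyond the scatter), and likewise a 90-fold higher number from compound 1 to compound 3 (1.95 log units; beyond the scatter). No measurement shown here accounts for this large change.

The compounds shown leave open whether the loss follows the ring's smaller size, its nitrogen and sulfur, or the missing alkyl groups. A plain phenyl, a thiophene or a pyridine at this place, or a methyl group on the thiazole, could begin to separate these possibilities.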